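A few compounds are considered here, and "the series" means these few. Any claim that something is new, unique, unknown or untested is made for them only; others in the source may bear on it.

Of the compounds shown here, two have so far been measured in a functional assay on the whole organism for inhibition, with Felis catus as the target, with a stated time of 30 min; on this read-out lower numbers stand for an effect already at smaller amounts and higher numbers for an effect only at larger amounts of compound. Compound 1 `Oc1ccc(OCC(O)CNCCOc2ccccc2)cc1` gives 0.031 mg/kg, and compound 2 `COCCNCC(O)COc1ccccc1` gives 0.13 mg/kg. Compound 2 therefore has the higher of the two numbers, and the gap to compound 1 lies beyond the usual scatter. These two differ in more than one place, so the gap cannot be tied to any single change. Compound 3 `COCCNCC(O)COc1ccc(O)cc1` is compound 2 with one edit: hydroxy in place of hydrogen on an aromatic carbon, a hydroxy in place of hydrogen on an aromatic carbon. Within the data shown here, no measured pair shows this change alone, so the expectation is loose. Compound 1, at 0.031 mg/kg, also carries this hydroxy, which suggests a moderately lower number rather than a higher one. The expected change is a 2.6-fold lower number from compound 2 to compound 3 (0.41 log units; beyond the scatter). For compound 3 the estimated value is 0.05 mg/kg, with an expected range of 0.012 mg/kg to 0.2 mg/kg.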

Compound 3, dose for half-maximal effect: 0.118 mg/kg
Compound 3: the middle estimate sits 2.4-fold (0.37 log units) below what was measured; the range from low to high includes it.
By their numbers in this assay, from the lowest: compound 1; then compounds 3 and 2 (each within the scatter of the next).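

Placed para to a large group on the aromatic ring, a hydroxy in place of hydrogen leaves the number essentially unchanged, with a 1.1-fold lower number from compound 2 to compound 3 (0.04 log units; within the scatter), so at this position the hydroxy on its own makes no clear difference. The clear gap instead appears with methyl in place of phenyl on an oxygen on a saturated carbon, which gives a 3.8-fold higher number from compound 1 to compound 3 (0.58 log units; beyond the scatter), and both of these compounds carry the hydroxy. No information at hand gives a reason for either step.

On these data alone, whether the hydroxy would have an equally small effect in a compound with phenyl on that oxygen stays open. So does whether an amine or a carboxylic acid at the same ring position, or a longer chain in place of methyl on the oxygen, would shift the number.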